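Fluorinated phenyl swap, compound 2 to compound 3

The source may report more compounds than this note shows. Statements on the series, on what has been measured and on what is new or still open speak of the compounds shown alone.

- compound 1 `CC(C)[C@H](NC(=O)COc1cccc2ccccc12)C(=O)N[C@@H](CC(=O)O)C(=O)COc1cccc(C(F)(F)F)c1`: 16600 nM
- compound 2 `CC(C)[C@H](NC(=O)COc1cccc2ccccc12)C(=O)N[C@@H](CC(=O)O)C(=O)COc1ccc(F)c(F)c1`: 16200 nM

In a functional assay with Homo sapiens as the target (a lower number here means a stronger inhibitor, a higher number a weaker inhibitor), the two measured compounds sit level, and compound 2, at 16200 nM, has no neighbour outside the scatter. Compound 3 `CC(C)[C@H](NC(=O)COc1cccc2ccccc12)C(=O)N[C@@H](CC(=O)O)C(=O)COc1c(F)cc(F)cc1F` brings one change: 2,4,6-trifluorophenyl in place of 3,4-difluorophenyl on an oxygen on a saturated carbon. Among the compounds with values here, the only measured step, an exchange at the same place, is a 1.0-fold lower number from compound 1 to compound 2 (0.01 log units; within the scatter). Within the data shown here, one step within the scatter is thin evidence, and no measured compound carries the entering group. No change beyond the scatter is therefore expected in this assay. The estimated step is a 1.1-fold lower number from compound 2 to compound 3 (0.03 log units; within the scatter). For compound 3 the expected value is 15000 nM, with an estimated range of 6000 nM to 40000 nM.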

Compound 3, half-maximal inhibitory concentration: 14900 nM
The estimate for compound 3 lay 1.0-fold (0.00 log units) above the measured number; low and high end bracket the measured number.
By their numbers in this assay, from the lowest: compounds 3, 2 and 1 (each within the scatter of the next).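

In this assay the new group gives a 1.1-fold lower number from compound 2 to compound 3 (0.04 log units; within the scatter) and a 1.1-fold lower number from compound 1 to compound 3 (0.05 log units; within the scatter) so three different fluorinated phenyl groups now sit level on this oxygen. Within the data shown here, the 2,4,6-trifluorophenyl group, the first with fluorine on three ring carbons, extends that level result beyond the single earlier exchange. No evidence is available on why the level holds.

All three groups shown are fluorinated phenyls, so a plain phenyl, or a phenyl carrying an amine or a carboxylic acid, remains open. As far as these compounds go, a saturated cyclohexyl ring at this place also remains open.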